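Chain extension from compound 3 to compound 4

The source may hold more compounds than are shown below. What is called first, only, known or untested is meant among the compounds shown, and "the series" means these compounds.

In a functional assay on SW480 cells (Homo sapiens) for antiproliferative activity, read by MTT assay, with a stated time of 48 h (a lower number here means a stronger inhibitor, a higher number a weaker inhibitor), compound 1 `CCC(CCO)n1cnc2c(Cl)ncnc21` gives > 50000 nM as a limit of the assay. Compound 2 `CCCCCCC(CCO)n1cnc2c(Cl)ncnc21` reads 16700 nM in this assay and sits above the next member. Compound 3 `CCCCCCCC(CCO)n1cnc2c(Cl)ncnc21` stands lowest at 3630 nM among the measured compounds.

The change to compound 4 `CCCCCCCCCCCCC(CCO)n1cnc2c(Cl)ncnc21` is pentyl in place of hydrogen on a saturated chain carbon, eight bonds along the chain from an aromatic nitrogen and leaves the shared core untouched. Among the compounds with values here, three measured steps bear on it, and all run the same way: an at least 2.9-fold lower number from compound 1 to compound 2 (0.47 log units; beyond the scatter) is at least modest, an at least 13-fold lower number from compound 1 to compound 3 (1.13 log units; beyond the scatter) is large, and a 4.6-fold lower number from compound 2 to compound 3 (0.66 log units; beyond the scatter) is modest. Within the data shown here, no measured compound carries a chain as long as that of compound 4, so the size of the step is uncertain and a reversal cannot be excluded.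

A further modest fall in this assay is expected because a 4.6-fold lower number from compound 2 to compound 3 (0.66 log units; beyond the scatter) came from a methyl alone. The estimated change is a 2.4-fold lower number from compound 3 to compound 4 (0.38 log units; beyond the scatter) in this series. Compound 4 is expected at 1500 nM with an estimated range of 350 nM to 7000 nM in this assay overall.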

Compound 4, half-maximal inhibitory concentration: > 50000 nM
Compound 4: no number, only a limit (the forecaster's own chance of this, stated with the estimate: 10%); middle value at least 33-fold (1.52 log units) away from the limit.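

In this assay the lengthening does not carry on past compound 3: pentyl in place of hydrogen on a saturated chain carbon, eight bonds along the chain from an aromatic nitrogen, gives an at least 13-fold higher number from compound 3 to compound 4 (1.13 log units; beyond the scatter), and hexyl at the carbon seven bonds along gives an at least 2.9-fold higher number from compound 2 to compound 4 (0.47 log units; beyond the scatter). The fall in the number from compound 1 through compound 2 to compound 3 therefore reverses at compound 4, so chain length at this position has an optimum within the range shown rather than a steady gain. Compound 4 gives only a limit of the assay, the same limit as compound 1, so the size of the rise stays unknown: the limit of > 50000 nM in this assay, at which 2 of the 4 values shown sit.

Open, from the compounds shown here alone, is whether a chain of a length between those of compound 3 and compound 4 would read lower than compound 3. Also open, going by these compounds, is whether an amine or a carboxylic acid in place of the added pentyl would keep the reading of compound 3.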